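A Triazole Diol Replaces the Piperazine Chain

The source may hold more compounds than are shown below. What is called first, only, known or untested is meant among the compounds shown, and "the series" means these compounds.

In a functional assay on SH-SY5Y cells (Homo sapiens) for cytotoxicity, read by MTT assay, with a stated time of 72 h (a lower number here means a stronger inhibitor, a higher number a weaker inhibitor), three compounds built on one shared core have been measured. Compound 1 `O=C1c2c[n+]([O-])c3ccccc3c2C(=O)c2c1c1ccccc1n2Cc1cn([C@H]2O[C@H](CO)[C@@H](O)[C@H]2O)nn1` gives 1340 nM, compound 2 `O=C1c2c[n+]([O-])c3ccccc3c2C(=O)c2c1c1ccccc1n2CCN1CCCC1` gives 520 nM, and compound 3 `CN1CCN(CCCn2c3c(c4ccccc42)C(=O)c2c[n+]([O-])c4ccccc4c2C3=O)CC1` gives 560 nM. Compound 3 thus stands level with compound 2 within the scatter, while its number is lower than that of compound 1.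

The next structure is compound 4 `O=C1c2c[n+]([O-])c3ccccc3c2C(=O)c2c1c1ccccc1n2Cc1cn(C[C@@H](O)CO)nn1`, and the change is 1-(2,3-dihydroxypropyl)-1H-1,2,3-triazol-4-yl in place of 2-(4-methylpiperazin-1-yl)ethyl on a saturated chain carbon bound to an aromatic nitrogen. For the measured compounds named here, only one measured step exists, a 1.1-fold higher number from compound 2 to compound 3 (0.03 log units; within the scatter). It exchanges one nitrogen ring chain for another, so it offers little guidance on the entering group. The better guide is compound 1, which also carries a 1H-1,2,3-triazol-4-yl group and gives 1340 nM. A move towards a higher number, beyond the scatter, is therefore expected in this assay. The expected size is a 2.0-fold higher number from compound 3 to compound 4 (0.29 log units; within the scatter). For compound 4 the estimated value is 1100 nM, with an expected range of 450 nM to 2700 nM.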

Compound 4, half-maximal inhibitory concentration: > 500 nM
Compound 4: a limit, no number; the forecaster's own chance of this, stated with the estimate: 3%; the middle value does not contradict the limit.
By their numbers in this assay, from the lowest: compounds 2 and 3 (each within the scatter of the next); then compound 1.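

In this assay, for the compounds shown here, compound 4 gives a limit and not a number, and no step to it from compound 1, compound 2 or compound 3 can be read: the limit of > 500 nM in this assay, at which 1 of the 4 values shown sits. The compounds shown leave open where compound 4 stands among these three compounds.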